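This account rests on a few compounds, and the source may have more. Where it says the series, first, only, none or still open, it means among the compounds named here.

Compounds measured so far in an assay on CHO-K1 cells for activation of DNA damage-inducible transcript 3 protein (Homo sapiens), read by a luciferase reporter; a higher number here means that more compound is needed for the effect, a lower number that less compound is needed:
compound 1, `O=C(Nc1ccc(S(=O)(=O)N2CCC(O)CC2)cc1)c1ccc([N+](=O)[O-])o1`, giving 2000 nM;
compound 2, `CC1CCN(S(=O)(=O)c2ccc(NC(=O)c3ccc([N+](=O)[O-])o3)cc2)CC1`, giving 700 nM.

Compound 2 holds the lower of the two numbers in this assay, the separation being a 2.9-fold lower number from compound 1 to compound 2 (0.46 log units; beyond the scatter). Compound 3, `CC1(C)CCN(S(=O)(=O)c2ccc(NC(=O)c3ccc([N+](=O)[O-])o3)cc2)CC1`, differs from compound 2 by methyl in place of hydrogen on a saturated ring carbon. For the measured compounds named here, only one measured step bears on this, and only loosely: a 2.9-fold lower number from compound 1 to compound 2 (0.46 log units; beyond the scatter) exchanged hydroxy for methyl, whereas here a methyl is added beside an existing one. Compound 3 is therefore expected to show a step of a 1.2-fold lower number from compound 2 to compound 3 (0.07 log units; within the scatter) in this assay, most likely within the scatter. The estimate for compound 3 is 600 nM, with a range from 250 nM to 1500 nM.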

Compound 3, concentration for half-maximal activity: 600 nM
For compound 3 middle estimate and measured number coincide at the digits printed; measured number inside the range.
By their numbers in this assay, from the lowest: compounds 3 and 2 (each within the scatter of the next); then compound 1.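

In this assay, the second methyl on this saturated ring carbon gives a 1.2-fold lower number from compound 2 to compound 3 (0.07 log units; within the scatter), so the position accepts 4,4-dimethylpiperidin-1-yl with the numbers of compound 2 and compound 3 level. The wider exchange of 4-hydroxypiperidin-1-yl for 4,4-dimethylpiperidin-1-yl gives a 3.3-fold lower number from compound 1 to compound 3 (0.52 log units; beyond the scatter), which shows that the gain seen with one methyl is kept with two. No evidence at hand accounts for either step.

Going by these compounds, whether an ethyl, a methoxy or an amine at this ring carbon would keep the number in this assay remains open.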